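The compounds below may be only part of what the source reports. "The series", "measured", "known", "first", "only" and "open" are said of these compounds alone.

Measured in an ADME assay on CCRF-HSB-2 cells (Homo sapiens) for cytotoxicity, with a stated time of 7 days; on this read-out higher numbers stand for lower toxicity in this test and lower numbers for higher toxicity in this test:
Compound 1 `Nc1nc(OCC(F)(F)F)c2ncn(/C=C3/CC3(CO)CO)c2n1`: > 20000 nM, a limit.
Compound 2 `CN(C)c1nc(N)nc2c1ncn2/C=C1/CC1(CO)CO`: > 20000 nM, a limit.
Compound 3 `Nc1nc(OCc2ccccc2)c2ncn(/C=C3/CC3(CO)CO)c2n1`: > 20000 nM, a limit.

Compound 3 has no exact number in this assay, and neither do the other two compounds. The whole set rests on one boundary, (the limit of > 20000 nM in this assay, at which 3 of the 3 values shown sit).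

The move to compound 4 `Nc1nc(NC2CCCC2)c2ncn(/C=C3/CC3(CO)CO)c2n1` is cyclopentylamino in place of benzyloxy on an aromatic carbon, which puts cyclopentylamino in place of benzyloxy on an aromatic carbon. The closest measured change at this place is a step that the two limits leave unreadable from compound 2 to compound 3, where benzyloxy takes the place of dimethylamino. Two further changes, a step that the two limits leave unreadable from compound 1 to compound 2 and a step that the two limits leave unreadable from compound 1 to compound 3, also alter this substituent. None of these three has a readable size, so they offer no magnitude to carry over, and no direction either.

Compound 4 is therefore expected to stay at the same limit, as compound 2 did with its amino-linked group in a step that the two limits leave unreadable from compound 1 to compound 2. The expected change is a step that the limit leaves unreadable from compound 3 to compound 4, with no direction that the data can support. For compound 4 the estimate is 25000 nM, with an expected range from 8000 nM to 60000 nM.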

Compound 4, half-maximal cytotoxic concentration: > 20000 nM
Compound 4: only a limit was reported; the forecaster's own chance of this, stated with the estimate: 75%; the middle value lies beyond the limit too.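

Going by these compounds alone, no step from compound 1, compound 2 or compound 3 to compound 4 can be read in this assay, because all four compounds rest on the same boundary: the limit of > 20000 nM in this assay, at which 4 of the 4 values shown sit. The compounds shown leave open whether these groups on the shared core change cytotoxicity at all, and in which direction.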